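A few compounds are considered here, and "the series" means these few. Any claim that something is new, unique, unknown or untested is made for them only; others in the source may bear on it.

Compound 1, `CCCC1=C(C(=O)OCC2CCCCC2)C(c2cccc(O)c2)NC(=O)N1`, in an ADME assay on CEMx174 cells (Homo sapiens) for cytotoxicity; a lower number here means that less compound is tolerated, a higher number that more compound is tolerated: > 10000 nM, a limit of the assay rather than a number.
Compound 2, `CCC1=C(C(=O)OCC2CCCCC2)C(c2cccc(O)c2)NC(=S)N1`, in this assay: > 10000 nM, again a limit of the assay.
Compound 3, `CCC1=C(C(=O)OCC2CCCCC2)C(c2cccc([N+](=O)[O-])c2)NC(=O)N1`, in this assay: > 10000 nM, also a limit of the assay.

Compound 3 therefore stands where every compound shown stands, at the limit of > 10000 nM in this assay, at which 3 of the 3 values shown sit. Going by the values given here, no single-change pair among the measured compounds gives a step to read from. The untested compound 4, `CCC1=C(C(=O)OCC2CCCCC2)C(c2ccc(C(=O)O)cc2)NC(=O)N1`, differs from compound 3 by 4-carboxyphenyl in place of 3-nitrophenyl on a saturated ring carbon. Among the compounds with values here, with no measured step to lean on, the expected change in this assay from compound 3 to compound 4 is none beyond the scatter, estimated as a step that the limit leaves unreadable from compound 3 to compound 4. Compound 4 is accordingly expected to give about 15000 nM, between 8000 nM and 40000 nM, most likely again as a limit.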

Compound 4, half-maximal cytotoxic concentration: > 10000 nM
Compound 4: a limit, no number; the forecaster's own chance of this, stated with the estimate: 80%; the middle value does not contradict the limit.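

No step can be read from compound 3 to compound 4 in this assay, as both values are limits of the assay: the limit of > 10000 nM in this assay, at which 4 of the 4 values shown sit.
The compounds shown leave open how much of any of them is actually tolerated, and whether any single change shifts that.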